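The source may report more compounds than this note shows. Statements on the series, on what has been measured and on what is new or still open speak of the compounds shown alone.

Compounds measured in an assay on SK-BR-3 cells for inhibition of Aromatase (Homo sapiens); on this read-out higher numbers stand for weaker inhibition and lower numbers for stronger inhibition:
- Compound 1, `CN(c1ccc([N+](=O)[O-])cc1OCc1ccc([N+](=O)[O-])cc1)S(C)(=O)=O`: 490 nM
- Compound 2, `CN(c1ccc([N+](=O)[O-])cc1OCc1ccc2ccccc2c1)S(C)(=O)=O`: 2680 nM
- Compound 3, `Cc1ccc(COc2cc([N+](=O)[O-])ccc2N(C)S(C)(=O)=O)cc1`: 2330 nM

Compound 3 stands second highest of the three numbers. Its nearest neighbour is compound 2, whose value lies within the scatter of that of compound 3, so the two cannot be ordered. Going by the values given here, compound 1 is furthest away, with a number clearly lower than that of compound 3, and the one measured single-point step, a 4.8-fold higher number from compound 1 to compound 3 (0.68 log units; beyond the scatter), describes exactly that gap: replacing nitro by methyl on the aromatic carbon raised the number by a modest but real amount.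

Compound 4, `CN(c1ccc([N+](=O)[O-])cc1OCc1ccc(F)cc1)S(C)(=O)=O`, has not been measured in this assay. It differs from compound 3 by fluoro in place of methyl on an aromatic carbon. Among the compounds with values here, no measured step replaces methyl by fluoro, so the expectation rests only on the fact that both compound 1 and compound 3 carry a single small substituent at this position and differ by a 4.8-fold higher number from compound 1 to compound 3 (0.68 log units; beyond the scatter). Fluoro is neither nitro nor methyl, so compound 4 is expected to fall somewhere between those two compounds, with a step of a 1.6-fold lower number from compound 3 to compound 4 (0.19 log units; within the scatter) from compound 3 that may not exceed the scatter. Compound 4 is therefore estimated at 1500 nM, within a range from 600 nM to 4000 nM.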

Compound 4, half-maximal inhibitory concentration: 1780 nM
Compound 4: the middle estimate sits 1.2-fold (0.07 log units) below what was measured, and the stated range covers the measured number.
By their numbers in this assay, from the lowest: compound 1; then compounds 4, 3 and 2 (each within the scatter of the next).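

In this assay, fluoro and methyl on this aromatic carbon, para to a large group, cannot be told apart: the change gives a 1.3-fold lower number from compound 3 to compound 4 (0.12 log units; within the scatter). Nitro at the same carbon now stands apart from two different small groups rather than one, as the second comparison gives a 3.6-fold higher number from compound 1 to compound 4 (0.56 log units; beyond the scatter), and the step from compound 1 to compound 3 had already shown a gap of similar standing. Among compound 1, compound 3 and compound 4, then, only the nitro compound carries the clearly lower number, although nothing here measures what lies behind that difference.

Going by these compounds, it remains open whether the lower number belongs to nitro alone or would also appear with another group at this carbon, such as a nitrile, a carboxylic acid or an amine. On these data alone, all four compounds also keep the shared core unchanged, so it is equally open whether the gap between nitro and the two smaller groups would survive a change elsewhere, for example replacing the nitro group on that core with an amine.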